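The source may hold more compounds than are shown below. What is called first, only, known or untested is meant among the compounds shown, and "the series" means these compounds.

Measured so far:
Compound 1 `NC(=O)CCNC(=O)c1cccc(S)c1`: in an ADME assay on CEM-SS cells (Homo sapiens) for cytotoxicity, read by XTT assay, with a stated time of 6 days (a lower number here means that less compound is tolerated, a higher number that more compound is tolerated), compound 1 gives > 100 uM, which is a limit of the assay and not a number.
Compound 2 `CCCC(=O)OCSc1ccccc1C(=O)NCCCCNC(C)=O`: in this assay compound 2 gives 17.4 uM.
Compound 3 `CCCC(=O)OCSc1ccccc1C(=O)N(C)CC(N)=O`: in this assay compound 3 gives 55.3 uM.

Compound 2 stands lowest of the two numbers in this assay, with compound 3 beyond the scatter above it. Compound 1 sits at a limit (the limit of > 100 uM in this assay, at which 1 of the 3 values shown sits).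

Compound 4 `CCCC(=O)OCSc1ccccc1C(=O)NCC(=O)NC(C)(C)C` is not yet measured. It differs from compound 2 as (tert-butyl)carbamoyl in place of 3-acetamidopropyl on a saturated chain carbon bound to an amide-type nitrogen; the two have the same atoms, joined differently, and the same difference, cut one bond further out, reads 4-acetamidobutyl to ((tert-butyl)carbamoyl)methyl. For the measured compounds named here, no measured step of this kind exists among the three compounds, so the step from compound 2 to compound 4 is expected to be small, near the scatter or slightly upward, a 1.4-fold higher number from compound 2 to compound 4 (0.16 log units; within the scatter). Compound 4 is estimated at 25 uM, within a range from 8 uM to 80 uM.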

Compound 4, half-maximal toxic concentration: 46.8 uM
The estimate for compound 4 lay 1.9-fold (0.27 log units) below the measured number; the range from low to high includes it.
By their numbers in this assay, from the lowest: compound 2; then compounds 4 and 3 (each within the scatter of the next). At a limit, above all of these: compound 1.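

For the compounds shown here, at this position, on a saturated chain carbon bound to an amide-type nitrogen, placing (tert-butyl)carbamoyl in place of 3-acetamidopropyl gives the first readable single change, in this assay: a 2.7-fold higher number from compound 2 to compound 4 (0.43 log units; beyond the scatter). The two groups have the same atoms and the same counted features, so that composition alone does not fix the number here. Nothing measured here accounts for the step.

Open, going by these compounds, is how this position responds to a terminal carboxylic acid or a primary amine. Whether a longer chain moves the number in either direction is also unsettled.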